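Pyrrolylcarbonyl in Place of a Benzothiophenylmethyl Group

The compounds below may be only part of what the source reports. "The series", "measured", "known", "first", "only" and "open" are said of these compounds alone.

Measured so far:
compound 1, `Clc1ccc2sc(CN3CCN(c4ncnc5c4CN(Cc4ccccc4)CC5)CC3)cc2c1`, gives 0%
compound 2, `O=C(CN1CCN(c2ncnc3c2CN(Cc2ccccc2)CC3)CC1)Nc1cc(F)ccc1F`, gives 0%

In an assay on isolated protein for inhibition of Rho-associated protein kinase 2 (Homo sapiens), read by HTRF, tested at 10 uM (on this read-out lower numbers stand for less inhibition and higher numbers for more inhibition at the one concentration tested (going by the name of the read-out)), compound 1 gives 0%, and compound 2 gives 0%. Compound 1 thus stands level with compound 2 at the digits recorded; the step of no change at the digits printed from compound 1 to compound 2 (within the scatter) lies within the scatter. These two differ in one place, with (2,5-difluorophenyl)carbamoyl in place of 5-chloro-1-benzothiophen-2-yl on a saturated chain carbon bound to an amine nitrogen in a ring.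

Compound 3, `Cc1cc(C(=O)N2CCN(c3ncnc4c3CN(Cc3ccccc3)CC4)CC2)c(C)n1C`, is not yet measured. It differs from compound 1 as follows: (1,2,5-trimethyl-1H-pyrrol-3-yl)carbonyl in place of (5-chloro-1-benzothiophen-2-yl)methyl on an amine nitrogen in a ring. Among the measured compounds shown here, the one measured step bears on this change only loosely: it shows that the group carried on the ring amine nitrogen of the shared core can be exchanged between two rather different substituents without any movement in this assay. For the measured compounds named here, neither measured compound shows inhibition at all, so no step of size beyond the scatter is expected from this exchange either. Compound 3 is therefore expected to give about 2%, in a range from -8% to 15%. The step of a number 2 percentage points higher from compound 1 to compound 3 (within the scatter) is the expected outcome, with no change beyond the scatter anticipated.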

Compound 3, a percentage reported as inhibition, at one concentration (the size of the read-out at that concentration, not a potency): 0%
Beside the measured number, compound 3's estimate is 2 percentage points above it; measured number inside the range.
By their numbers in this assay, from the lowest: compounds 1, 2 and 3 (each within the scatter of the next).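

The step of no change at the digits printed from compound 1 to compound 3 (within the scatter) in this assay takes the test of this position beyond the earlier pair. There, the chain carbon bound to the amine nitrogen in a ring stayed in place and only the group on it was exchanged, whereas here the whole (5-chloro-1-benzothiophen-2-yl)methyl group leaves and a (1,2,5-trimethyl-1H-pyrrol-3-yl)carbonyl group enters, with its carbonyl directly on that nitrogen. Neither this new connection nor the loss of the six-membered aromatic ring of carbon only gives a reading different from that of compound 1, so the shared core has still shown no inhibition with any group tested on this nitrogen. Nothing available explains this result. Since these readings sit at the bottom of the scale, they cannot show whether any of these groups matters to the kinase, and a sulfonyl group or a chain ending in a primary amine on this nitrogen remains an open case. From the compounds shown here alone, it also remains open whether a carboxylic acid or a primary amine placed elsewhere on the shared core would give any measurable inhibition.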